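The compounds below may be only part of what the source reports. "The series", "measured", "known", "first", "only" and "open" are said of these compounds alone.

Measured compounds:
- compound 1, `Cc1cc(CN/C(S)=N/Cc2ccc(NS(C)(=O)=O)cc2)c(COC(=O)C(C)(C)C)cc1C`, gives 70000 nM in a functional assay for inhibition of Vanilloid receptor (Rattus norvegicus); on this read-out lower numbers stand for stronger inhibition and higher numbers for weaker inhibition
- compound 2, `CCCCCCOc1cc(C(C)(C)C)ccc1C/N=C(\S)NCc1ccc(NS(C)(=O)=O)cc1`, gives 150 nM in this assay
- compound 3, `CC(C)Oc1cc(C(C)(C)C)ccc1C/N=C(\S)NCc1ccc(NS(C)(=O)=O)cc1`, gives 350 nM in this assay

Compound 3 stands second highest of the three numbers. Its nearest neighbour is compound 2, and the step is a 2.3-fold higher number from compound 2 to compound 3 (0.37 log units; beyond the scatter). Within the data shown here, compound 1 lies far away with a much higher number, but it differs from compound 3 in several places at once, so no single step joins them.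

Compound 4, `CC(=O)OCc1cc(C(C)(C)C)ccc1C/N=C(\S)NCc1ccc(NS(C)(=O)=O)cc1`, has not yet been measured. It differs from compound 3 in one place: acetoxymethyl in place of isopropoxy on an aromatic carbon. Among the measured compounds shown here, the only single step seen so far, a 2.3-fold higher number from compound 2 to compound 3 (0.37 log units; beyond the scatter), swaps one chain for another on the same oxygen and does not bear directly on an ester group entering in place of an ether. For the measured compounds named here, compound 1 is the only measured compound that carries an ester at the corresponding position, and it gives 70000 nM, but its other differences make it a weak guide. The expectation is therefore a modest rise in the number, larger than the step seen between compounds 2 and 3, with wide uncertainty. For compound 4 the estimated value in this assay is 1200 nM, within a range of 300 nM to 6000 nM, which means an expected step of a 3.4-fold higher number from compound 3 to compound 4 (0.54 log units; beyond the scatter).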

Compound 4, half-maximal inhibitory concentration: 580 nM
For compound 4 the middle estimate is 2.1-fold (0.32 log units) above the measured one; the measured number falls inside the stated range.
By their numbers in this assay, from the lowest: compound 2; then compounds 3 and 4 (each within the scatter of the next); then compound 1.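

Placing acetoxymethyl on this aromatic carbon, ortho to a large group, in place of isopropoxy gives a 1.7-fold higher number from compound 3 to compound 4 (0.22 log units; within the scatter) in this assay, so compound 3 and compound 4 cannot be told apart on this read-out. This position therefore does not depend on an ether group: a group that carries a carbonyl, which isopropoxy lacks, serves about as well here. The longer hexyloxy group still stands apart, with a 3.9-fold higher number from compound 2 to compound 4 (0.59 log units; beyond the scatter), and that step together with a 2.3-fold higher number from compound 2 to compound 3 (0.37 log units; beyond the scatter) leaves compound 2 with a lower number than either of the two shorter groups, although no evidence at hand explains why these groups compare as they do.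

The compounds shown leave open which part of acetoxymethyl matters, since a plain hydroxymethyl or methoxymethyl group would separate the carbonyl from the rest of the chain. They also leave open how far this position tolerates other kinds of group, such as an amine or a carboxylic acid, and whether an ester with a longer chain would bring the number closer to that of compound 2.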